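The source may report more compounds than this note shows. Statements on the series, on what has been measured and on what is new or still open speak of the compounds shown alone.

Working notes on the series. In a functional assay on MCF7 cells (Homo sapiens) for antiproliferative activity, read by sulforhodamine B assay, with a stated time of 48 h (a lower number here means a stronger inhibitor, a higher number a weaker inhibitor), compound 1 (`O=C1NCCN1c1ccc(S(=O)(=O)Nc2ccc(Br)cc2)cc1`) gives 240 nM against compound 2 (`Cc1ccc(C)c(NS(=O)(=O)c2ccc(N3CCNC3=O)cc2)c1`) at 48 nM and so compound 2 holds the lower of the two numbers. The next compound is compound 3 (`Cc1ccccc1NS(=O)(=O)c1ccc(N2CCNC2=O)cc1`), which has hydrogen in place of methyl on an aromatic carbon, para to a methyl group, taking 2,5-dimethylphenyl to 2-methylphenyl (hydrogen in place of methyl on an aromatic carbon). Among the measured compounds shown here, the only measured step is a 5.0-fold lower number from compound 1 to compound 2 (0.70 log units; beyond the scatter) and it lies beyond the scatter. That step replaces the whole group on the sulfonamide nitrogen, so no measurement isolates the loss of one methyl. For the measured compounds named here, it gives only weak support for a modest rise, no larger than that step. In this assay the expected change is a 1.9-fold higher number from compound 2 to compound 3 (0.27 log units; within the scatter) as a rough estimate. For compound 3 the estimated value is 90 nM (range 30 nM to 270 nM).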

Compound 3, half-maximal inhibitory concentration: 280 nM
Beside the measured number, compound 3's estimate is 3.1-fold (0.49 log units) below it, and the stated range ends below it.
By their numbers in this assay, from the lowest: compound 2; then compounds 1 and 3 (each within the scatter of the next).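

Taken alone, the methyl para to a methyl group matters in this assay: the change from 2,5-dimethylphenyl to 2-methylphenyl gives a 5.8-fold higher number from compound 2 to compound 3 (0.77 log units; beyond the scatter) and is the first measured step at this single position. With a 1.2-fold higher number from compound 1 to compound 3 (0.07 log units; within the scatter) as the comparison, 2-methylphenyl on the sulfonamide nitrogen does not keep the lower number of compound 2, which here depends on the second methyl being present. No measured evidence on the cause of this change is at hand.

On these data alone, whether a methoxy group, a chlorine atom or a longer chain such as ethyl on this aromatic carbon would hold the number of compound 2 remains open. Also open is what the remaining methyl contributes, since every comparison shown at this ring keeps it or exchanges the whole group.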